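This account rests on a few compounds, and the source may have more. Where it says the series, first, only, none or still open, it means among the compounds named here.

Measured so far:
- compound 1 `CN1CCN(CC(=O)Nc2ccc(-c3nc4cc(C(F)(F)F)ccc4n3C)cc2)CC1`: 22000 nM
- compound 2 `O=C(Nc1ccc(-c2nc3cc(C(F)(F)F)ccc3[nH]2)cc1)Nc1ccc(-c2nc3cc(C(F)(F)F)ccc3[nH]2)cc1`: > 100000 nM

In an ADME assay on MT4 cells (Homo sapiens) for cytotoxicity, read by MTT assay, with a stated time of 96 h (a lower number here means that less compound is tolerated, a higher number that more compound is tolerated), compound 1 gives 22000 nM. Compound 2, in contrast, gives only a limit of the measurement, > 100000 nM, so no number is known for it. For the measured compounds named here, compound 1 therefore holds the only number in this assay; the other value is the limit of > 100000 nM in this assay, at which 1 of the 2 values shown sits. Going by the values given here, no pair of measured compounds differs in a single place, so no measured step is available to guide an expectation.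

Compound 3 `Cn1c(-c2ccc(NC(=O)CN3CCCCC3)cc2)nc2cc(C(F)(F)F)ccc21` has not yet been measured. It differs from compound 1 in one place: piperidin-1-yl in place of 4-methylpiperazin-1-yl on a saturated chain carbon bound to a carbonyl carbon. The change removes the second ring nitrogen with its methyl group and leaves the rest of the shared core untouched. The step from compound 1 to compound 3 in this assay is expected to be small, at most a modest move toward less tolerated, or none beyond the usual scatter, a 1.5-fold lower number from compound 1 to compound 3 (0.17 log units; within the scatter). Compound 3 is thus estimated to give 15000 nM, between 5000 nM and 60000 nM.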

Compound 3, half-maximal cytotoxic concentration: 9000 nM
For compound 3 the middle estimate is 1.7-fold (0.22 log units) above the measured one; the range from low to high includes it.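

In this assay, placing piperidin-1-yl instead of 4-methylpiperazin-1-yl on the saturated chain carbon bound to a carbonyl carbon gives a 2.4-fold lower number from compound 1 to compound 3 (0.39 log units; beyond the scatter). For the compounds shown here, this is the first step available here, and it shows that the number responds to the group at this position, though only modestly. The shared core stays the same, so the step belongs to this one exchange, which removes the second ring nitrogen together with its methyl group, but nothing in the data shown explains why the number moves.

The compounds shown leave open whether the step follows the lost ring nitrogen or the lost methyl group. A piperazin-1-yl ring with no methyl group, or a morpholin-4-yl ring, in the same place would help tell these two apart.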